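This account rests on a few compounds, and the source may have more. Where it says the series, first, only, none or still open, it means among the compounds named here.

Measured in a functional assay on HeLa cells (Homo sapiens) for antiproliferative activity, read by sulforhodamine B assay (a lower number here means a stronger inhibitor, a higher number a weaker inhibitor), so far:
- compound 1 `C/C(=N\Nc1nc2ccccc2o1)c1cnc(C)cn1` gives 370 nM
- compound 2 `c1ccc(C(=NNc2nc3ccccc3o2)c2ccccn2)nc1` gives 156 nM

Compound 1 holds the higher of the two numbers and so is the weaker inhibitor here, and its gap to compound 2 lies beyond the scatter. Compound 3 `C/C(=N\Nc1nc2ccccc2o1)c1cnccn1` has not yet been measured in this assay and differs from compound 1 in one place: hydrogen in place of methyl on an aromatic carbon in words, hydrogen in place of methyl on an aromatic carbon. Going by the values given here, no two measured compounds differ in one place only, so the data give no direct reading of this change. No shift beyond the scatter is expected in either direction. The estimated step runs a 1.2-fold lower number from compound 1 to compound 3 (0.09 log units; within the scatter) and is expected to stay within the scatter. For compound 3 the estimate is 300 nM with an expected range of 130 nM to 700 nM for the measurement.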

Compound 3, half-maximal inhibitory concentration: 690 nM
Estimate against measurement, compound 3: 2.3-fold (0.36 log units) below; measured number inside the range.
By their numbers in this assay, from the lowest: compound 2; then compounds 1 and 3 (each within the scatter of the next).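

In this assay, going by these compounds alone, the pair gives the first direct reading of hydrogen in place of methyl on an aromatic carbon of the six-membered aromatic ring with 2 nitrogen, para to a large group (a 1.9-fold higher number from compound 1 to compound 3 (0.27 log units; within the scatter)). On this single pair, the position therefore tolerates the loss of methyl with no shift that clears the usual scatter, and methyl is not shown to be needed here. No measurement available bears on what lies behind this reading.

As far as these compounds go, only hydrogen and methyl are compared at this position, so whether an amine, a methoxy group, chlorine or a longer chain there would give a clear shift remains open. Also open, from the compounds shown here alone, is whether the same change reads alike in other members.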